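Trimming cyclopropyl to methyl on an amide

This account rests on a few compounds, and the source may have more. Where it says the series, first, only, none or still open, it means among the compounds named here.

Compound 2 (`CNC(=O)c1cc(C(=O)NC2CC2)cc2c1OC[C@H]2c1ccccc1`) gives 3.6 in a physicochemical assay for lipophilicity, at pH 7.4 (on this read-out lower numbers stand for lower lipophilicity and higher numbers for higher lipophilicity), and sits within the scatter of its only measured relative, compound 1 (`CNC(=O)c1cc(C(=O)N[C@H]2[C@@H]3COC[C@@H]32)cc2c1OC[C@H]2c1ccccc1`), at 3.3 on the same scale. Compound 3 (`CNC(=O)c1cc(C(=O)NC)c2c(c1)[C@H](c1ccccc1)CO2`) has not yet been measured. It differs from compound 2 in one place (methyl in place of cyclopropyl on an amide-type nitrogen): methyl in place of cyclopropyl on an amide-type nitrogen. Among the compounds with values here, one measured step bears on this, at the same nitrogen (a number 0.30 log units higher from compound 1 to compound 2 (within the scatter)), but it is a different swap and stays within the scatter, so it is only a loose guide. Within the data shown here, nothing measured so far carries methyl on that nitrogen. With compound 2 at 3.6 as the starting point, a modest downward step is expected. The expected change (a number 0.60 log units lower from compound 2 to compound 3 (beyond the scatter)) may just clear the scatter. The estimate for compound 3 is 3 in this assay with 2.6 to 3.4 as the expected range.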

Compound 3, distribution coefficient: 3.2
Compound 3: middle estimate off by 0.20 log units, on the low side; measured number inside the range.
By their numbers in this assay, from the lowest: compounds 3, 1 and 2 (each within the scatter of the next, the first and the last beyond it).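

In this assay, this position now shows a step that clears the usual scatter: methyl in place of cyclopropyl on the amide-type nitrogen gives a modest change (a number 0.40 log units lower from compound 2 to compound 3 (beyond the scatter)). Size alone does not set the number across these three compounds, since the large group containing oxygen and the single carbon cannot be told apart (a number 0.10 log units lower from compound 1 to compound 3 (within the scatter)), while cyclopropyl, of intermediate size, goes against any simple trend with size. No measurement is available to explain why these groups give these numbers.

As far as these compounds go, it remains open where an ethyl group, a longer chain carrying an amine, or a carboxylic acid on that nitrogen would fall in this assay. From the compounds shown here alone, it is also open whether the cyclopropyl-to-methyl step would keep its size on a different core.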